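The compounds below may be only part of what the source reports. "The series", "measured", "known", "first", "only" and "open" are said of these compounds alone.

Compound 1 `O=C1CCCN1Cc1ncnc2c1ncn2[C@@H]1O[C@H](CO)[C@@H](O)[C@H]1O` carries a 2-oxopyrrolidin-1-yl group on a saturated chain carbon bound to an aromatic carbon of the shared core. Among the compounds with values here, in a functional assay on Huh-7 cells (Homo sapiens) for cytotoxicity, read by MTT assay, with a stated time of 3 days (a lower number here means that less compound is tolerated, a higher number that more compound is tolerated), compound 1 gives 45000 nM, and this is the only plain number recorded in this assay. Compound 2 `CC(=O)N(Cc1ncnc2c1ncn2[C@H]1C[C@H](O)[C@@H](CO)O1)C1CCCCC1` is the second compound tested. For compound 2 this assay reports only a limit, > 100000 nM, and so there is the limit of > 100000 nM in this assay, at which 1 of the 2 values shown sits. Compound 3 `O=c1ccccn1Cc1ncnc2c1ncn2[C@@H]1O[C@H](CO)[C@@H](O)[C@H]1O` has not yet been tested in this assay. It differs from compound 1 by a group of 7 heavy atoms (5 carbon, 1 nitrogen, 1 oxygen; one six-membered aromatic ring with 1 hetero atom) in place of a group of 6 heavy atoms (4 carbon, 1 nitrogen, 1 oxygen; one five-membered non-aromatic ring with 1 hetero atom), on a saturated chain carbon bound to an aromatic carbon. Within the data shown here, no step between two measured compounds is available to show what such a change does to the tolerated concentration. In this assay the change is expected to amount to a 1.1-fold higher number from compound 1 to compound 3 (0.05 log units; within the scatter), with no direction that stands out beyond the usual scatter. Compound 3 is therefore estimated at 50000 nM in this assay, within a range from 20000 nM to 150000 nM.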

Compound 3, half-maximal cytotoxic concentration: > 100000 nM
Compound 3 gave a limit, no number (the forecaster's own chance of this, stated with the estimate: 35%); middle value at least 2.0-fold (0.30 log units) away from the limit.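

Within the data shown here, this is the first step read at this position on a saturated chain carbon bound to an aromatic carbon. In this assay, the six-membered aromatic ring with 1 hetero atom in place of the 2-oxopyrrolidin-1-yl group gives an at least 2.2-fold higher number from compound 1 to compound 3 (0.34 log units; beyond the scatter), so the group carried here can shift the tolerated concentration beyond the usual scatter. Among these compounds, the step has a lower bound only, and the top of the range now holds most of the results, leaving compound 1 as the only plain number: the limit of > 100000 nM in this assay, at which 2 of the 3 values shown sit.

The change alters ring size and aromatic character together, and the compounds shown do not separate the two. As far as these compounds go, a piperidin-2-one ring would bear on that question, while it remains open how a simple amine or a carboxylic acid at this place would read in this assay.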